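This account rests on a few compounds, and the source may have more. Where it says the series, first, only, none or still open, it means among the compounds named here.

Compound 1 `C[C@@H]1CN(c2ccc(Cl)c(NS(=O)(=O)c3ccc(-c4ccccn4)s3)c2)C[C@H](C)N1`: 39.8 nM
Compound 2 `C[C@@H]1CN(c2ccc(F)c(NS(=O)(=O)c3ccc(-c4ccccn4)s3)c2)C[C@H](C)N1`: 100 nM

Among these two compounds, compound 2 gives the higher number in a functional assay for agonist activity at growth hormone secretagogue receptor type 1 (Homo sapiens), read by FLIPR; on this read-out lower numbers stand for an effect already at smaller amounts and higher numbers for an effect only at larger amounts of compound; its nearest neighbour is compound 1, and the single measured step is a 2.5-fold higher number from compound 1 to compound 2 (0.40 log units; beyond the scatter). Compound 3 `CC(=O)c1ccc(N2C[C@@H](C)N[C@@H](C)C2)cc1NS(=O)(=O)c1ccc(-c2ccccn2)s1` differs from compound 2 in one place: acetyl in place of fluoro on an aromatic carbon. Among the compounds with values here, no measured step swaps fluoro for acetyl, and the one known step, fluoro in place of chloro, bears on it only loosely. The expected step is therefore a 1.7-fold lower number from compound 2 to compound 3 (0.22 log units; within the scatter), with little confidence in its direction. Compound 3 is estimated at 60 nM, ranging from 15 nM to 250 nM.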

Compound 3, half-maximal effective concentration: 39.8 nM
For compound 3 the middle estimate is 1.5-fold (0.18 log units) above the measured one, and the stated range covers the measured number.
By their numbers in this assay, from the lowest: compounds 1 and 3 (each within the scatter of the next); then compound 2.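

In this assay, acetyl, with more heavy atoms than fluoro, is tolerated at the position para to the 3,5-dimethylpiperazin-1-yl group, giving a 2.5-fold lower number from compound 2 to compound 3 (0.40 log units; beyond the scatter). Swapping chloro for acetyl gives no change at the digits printed from compound 1 to compound 3 (within the scatter), so among these three compounds, fluoro is the one that stands apart, while chloro and acetyl read alike. No measurement shown here accounts for this result. Still open, going by these compounds, is how an amine or a carboxylic acid would read at this position. On these data alone, a longer chain in place of acetyl is equally open.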